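Compound 3 to compound 4: 2,4,6-trimethylphenyl on the nitrogen

A few compounds are considered here, and "the series" means these few. Any claim that something is new, unique, unknown or untested is made for them only; others in the source may bear on it.

Going by the values given here, in a functional assay on MCF7 cells (Homo sapiens) for inhibition, read by CCK-8 assay, with a stated time of 48 h (a lower number here means a stronger inhibitor of growth, a higher number a weaker inhibitor of growth), compound 3 (`Cc1cccc(Nc2nc(Nc3ccc(N4CCN(C)CC4)cn3)ncc2Cl)c1`) has the lowest number so far at 7160 nM, and compound 1 (`CN1CCN(c2ccc(Nc3ncc(Cl)c(NCc4ccccc4)n3)nc2)CC1`) is the nearest at 17300 nM. Compound 2 (`COc1ccccc1CNc1nc(Nc2ccc(N3CCN(C)CC3)cn2)ncc1Cl`) reads > 100000 nM, which is a limit of the assay.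

Compound 4 (`Cc1cc(C)c(Nc2nc(Nc3ccc(N4CCN(C)CC4)cn3)ncc2Cl)c(C)c1`) has 2,4,6-trimethylphenyl in place of 3-methylphenyl on a nitrogen on an aromatic ring.

Among the compounds with values here, no measured step makes this exact change, so the evidence is indirect. Within the data shown here, the closest precedent is methoxy in place of hydrogen on an aromatic carbon, which gave an at least 5.7-fold higher number from compound 1 to compound 2 (0.76 log units; beyond the scatter). Exchanging the group on the same nitrogen gave a 2.4-fold lower number from compound 1 to compound 3 (0.38 log units; beyond the scatter) and an at least 13-fold lower number from compound 2 to compound 3 (1.14 log units; beyond the scatter). These steps show that this assay responds to changes at this nitrogen and that one added aromatic substituent moved the number upward. However, methoxy is a different group from those in this change, and that step was measured on a benzyl rather than a phenyl group. A modest rise is therefore expected, with a real chance of a result within the scatter.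

The estimated step is a 2.0-fold higher number from compound 3 to compound 4 (0.29 log units; within the scatter). For compound 4, the expected value is 14000 nM, with an estimated range of 4000 nM to 60000 nM.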

Compound 4, concentration for 50% growth inhibition: 9470 nM
The estimate for compound 4 lay 1.5-fold (0.17 log units) above the measured number, within the range that was stated.
By their numbers in this assay, from the lowest: compounds 3, 4 and 1 (each within the scatter of the next, the first and the last beyond it). At a limit, above all of these: compound 2.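

In this assay, going by these compounds alone, the step to the more heavily substituted phenyl group gives a 1.3-fold higher number from compound 3 to compound 4 (0.12 log units; within the scatter), so the rise seen for methoxy on the benzyl group of compound 2 has no counterpart in this change on the phenyl group. Compound 4 also sits close to the benzyl compound, with a 1.8-fold lower number from compound 1 to compound 4 (0.26 log units; within the scatter), so the separation between compound 3 and compound 1 does not extend to every phenyl group at this nitrogen. The step of an at least 10-fold lower number from compound 2 to compound 4 (1.02 log units; beyond the scatter) holds only as a bound, since compound 2 stands at a limit of the assay: the limit of > 100000 nM in this assay, at which 1 of the 4 values shown sits.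

Across the compounds shown, the group on this nitrogen carries only methyl or methoxy substituents, and methyl appears only on phenyl and methoxy only on benzyl, so the effect of methoxy on a phenyl group stays open. Also open, from the compounds shown here alone, is whether an amine or a carboxylic acid on the phenyl group, or a longer chain between the nitrogen and the ring, would move the number beyond the scatter from compound 3, and the rest of the shared core does not vary here.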